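The source may hold more compounds than are shown below. What is called first, only, known or untested is meant among the compounds shown, and "the series" means these compounds.

Working notes on the series.

Two compounds have numbers or limits so far. Compound 1 `C=CCCC(=O)N[C@H]1[C@@H](OCCCCCCCCCCCCCCCC)O[C@H](CO)[C@@H](O)[C@@H]1O` is measured in a functional assay on U-373MG ATCC cells (Homo sapiens), read by thymidine incorporation; on this read-out lower numbers stand for stronger inhibition and higher numbers for weaker inhibition; for compound 1 the assay reports only a limit, > 50 uM, not a number. For the measured compounds named here, compound 2 `CCCCCCCCCCCCCCCCO[C@H]1O[C@H](COCC(CO)(CO)COS(=O)(=O)O)[C@@H](O)[C@H](O)[C@H]1NC(=O)CCCC` is the only compound with a numeric value: in this assay compound 2 gives 3.2 uM. Going by the values given here, with one number and one limit (the limit of > 50 uM in this assay, at which 1 of the 2 values shown sits), compound 2 stands as the sole numeric point, and no step between measured compounds can be computed.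

Compound 3 `CCCCCCCCCCCCCCCCO[C@H]1O[C@H](COC[C@@H](O)CO)[C@@H](O)[C@H](O)[C@H]1NC(=O)CCCC` is not yet measured. It differs from compound 2 by a single change, (1,2-dihydroxyethyl in place of 2-hydroxy-1-(hydroxymethyl)-1-((sulfooxy)methyl)ethyl on a saturated chain carbon bound to an oxygen on a saturated carbon); that is, 1,2-dihydroxyethyl in place of 2-hydroxy-1-(hydroxymethyl)-1-((sulfooxy)methyl)ethyl on a saturated chain carbon bound to an oxygen on a saturated carbon. Among the compounds with values here, no measured pair shows the effect of this change, and compound 1, which carries a plain hydroxymethyl at that region, also differs from compound 2 elsewhere, so its limit cannot be read as a step for this change alone.

The estimate for compound 3 in this assay is 15 uM, within a range of 4 uM to 50 uM, which means an expected step of a 4.7-fold higher number from compound 2 to compound 3 (0.67 log units; beyond the scatter) towards weaker inhibition, beyond the usual scatter but with considerable uncertainty; a limit rather than a number is a real possibility.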

Compound 3, concentration for 50% inhibition: 5.6 uM
Compound 3: middle estimate off by 2.7-fold (0.43 log units), on the high side; low and high end bracket the measured number.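

In this assay, placing 1,2-dihydroxyethyl in place of 2-hydroxy-1-(hydroxymethyl)-1-((sulfooxy)methyl)ethyl on a saturated chain carbon bound to an oxygen on a saturated carbon gives a 1.8-fold higher number from compound 2 to compound 3 (0.24 log units; within the scatter), so the two compounds cannot be told apart on this read-out. In this pair, the sulfooxy group and the branched group that carries it are therefore not required for a value at this level, even though the group falls from 11 heavy atoms to 4. Compound 1 remains a limit and not a number, and it differs from compound 3 in more than this region, so it gives no step for this change: the limit of > 50 uM in this assay, at which 1 of the 3 values shown sits.

On these data alone, it remains open how far the value depends on the hydroxyl groups of 1,2-dihydroxyethyl, which a plain ethyl group or a carboxylic acid at this place would test, and whether a sulfooxy group on a shorter, unbranched chain would read the same. The opposite configuration at the defined stereocentre of 1,2-dihydroxyethyl is also an open question.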